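This account rests on a few compounds, and the source may have more. Where it says the series, first, only, none or still open, it means among the compounds named here.

Measured in a functional assay on HT-29 cells (Homo sapiens) for inhibition, read by MTT assay, with a stated time of 3 days; a lower number here means a stronger inhibitor, a higher number a weaker inhibitor:
compound 1 `COc1ccc(/C=C\c2cc(OC)c(OC)c(OC)c2)cc1OCc1ccc(Br)cc1`: 108000 nM
compound 2 `COc1ccc(/C=C/CCCOc2cc(/C=C\c3cc(OC)c(OC)c(OC)c3)ccc2OC)cc1`: 47000 nM
compound 3 `COc1ccc(/C=C\c2cc(OC)c(OC)c(OC)c2)cc1OCCC/C=C/c1ccc(F)cc1`: 98000 nM

Compound 3 sits with compound 1 at the high end of these three numbers, and compound 2 lies lower. Compound 4 `COc1ccc(/C=C\c2cc(OC)c(OC)c(OC)c2)cc1OCCC/C=C/c1ccc(Cl)cc1` carries chloro in place of fluoro on an aromatic carbon, para to a large group: chloro in place of fluoro on an aromatic carbon. The closest evidence is the swap at that same carbon, a 2.1-fold higher number from compound 2 to compound 3 (0.32 log units; beyond the scatter), which is modest. The larger change of the whole side chain gave a 1.1-fold lower number from compound 1 to compound 3 (0.04 log units; within the scatter). No swap of one halogen for another at this carbon has been measured, and no shift beyond the scatter is expected in this assay. The expected step is a 1.0-fold lower number from compound 3 to compound 4 (0.01 log units; within the scatter). Compound 4 is estimated at 95000 nM, with an expected range of 50000 nM to 170000 nM.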

Compound 4, half-maximal inhibitory concentration: 18000 nM
The estimate for compound 4 lay 5.3-fold (0.72 log units) above the measured number, outside the stated range (below it).
By their numbers in this assay, from the lowest: compound 4; then compound 2; then compounds 3 and 1 (each within the scatter of the next).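

In this assay, the halogen at the end of the side chain matters: chloro in place of fluoro gives the first large shift among these compounds (a 5.4-fold lower number from compound 3 to compound 4 (0.74 log units; beyond the scatter)). The chloro compound also separates from the methoxy compound (a 2.6-fold lower number from compound 2 to compound 4 (0.42 log units; beyond the scatter)) and from the 4-bromophenyl compound (a 6.0-fold lower number from compound 1 to compound 4 (0.78 log units; beyond the scatter)), so the side chain's effect depends on this substituent. No data shown here explain the difference between chloro and fluoro at this carbon.
Still open, from the compounds shown here alone, is whether bromo or an amine at this carbon would follow chloro or fluoro. Also open, going by these compounds, is whether a longer chain would preserve the chloro result.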